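The source may report more compounds than this note shows. Statements on the series, on what has been measured and on what is new or still open speak of the compounds shown alone.

Measured so far:
Compound 1 `Cc1cc(=O)[nH]c(=O)n1COC(CO)CO` in a functional assay on MIA PaCa-2 cells (Homo sapiens) for inhibition, read by MTT assay, with a stated time of 72 h (on this read-out lower numbers stand for stronger inhibition and higher numbers for weaker inhibition), gives > 100000 nM, a limit of the assay.
Compound 2 `NCC(=O)Nc1c[nH]c(=O)[nH]c1=O` in this assay gives > 100000 nM, also a limit.
Compound 3 `O=c1ccn(COC(CO)CO)c(=O)[nH]1` in this assay gives > 100000 nM, again a limit.

Compound 2 therefore stands only at a limit in this assay, and so do the other two values shown, as the limit of > 100000 nM in this assay, at which 3 of the 3 values shown sit, records. Among the compounds with values here, the one step between measured compounds, a step that the two limits leave unreadable from compound 1 to compound 3, is unreadable for the same reason, so no measured step gives a usable size for any change.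

Compound 4 `O=C(CCl)Nc1c[nH]c(=O)[nH]c1=O` differs from compound 2 by chloro in place of amino on a saturated chain carbon bound to a carbonyl carbon. Within the data shown here, no measured step bears on this change, and the starting point itself is a limit, so no direction or size of step in this assay can be read from the data. The expectation for compound 4 is that this assay again returns a limit, which is the step of an at least 1.2-fold lower number from compound 2 to compound 4 (0.09 log units; that floor lies within the scatter) taken as expected. Compound 4 is estimated at 80000 nM, within 15000 nM to 200000 nM.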

Compound 4, half-maximal inhibitory concentration: 17000 nM
Estimate against measurement, compound 4: 4.7-fold (0.67 log units) above; the range from low to high includes it.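

Of the compounds shown, only compound 4 gives a number rather than a limit in this assay: the limit of > 100000 nM in this assay, at which 3 of the 4 values shown sit.

Within the data shown here, the saturated chain carbon bound to a carbonyl carbon is the first place where a change can be sized, with an at least 5.8-fold lower number from compound 2 to compound 4 (0.76 log units; beyond the scatter). Chloro in place of amino is enough on its own to bring the read-out inside the measurable range, and the step is beyond the usual scatter; it starts from a limit, so its full size stays unknown.

From the compounds shown here alone, whether this follows from chloro entering or from amino leaving stays open: bromo, hydroxyl or methyl in the same place would separate the two. The compounds shown also do not tell why the number falls, or what a longer chain carrying the chloro would give.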